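Trading 4-hydroxyphenyl for 2-hydroxyphenyl

The source may hold more compounds than are shown below. What is called first, only, known or untested is meant among the compounds shown, and "the series" means these compounds.

Of the compounds shown here, three sharing one core have been tested in a functional assay on A549 cells (Homo sapiens) for inhibition, read by MTT assay, with a stated time of 24 h; on this read-out higher numbers stand for weaker inhibition and lower numbers for stronger inhibition: compound 1 `CC1(C)[C@H]2CC[C@]1(C)N(Cc1cn(-c3ccc(F)cc3)nn1)C(=O)C2` gives 230 nM, compound 2 `CC1(C)[C@H]2CC[C@]1(C)N(Cc1cn(-c3ccccc3Cl)nn1)C(=O)C2` gives 70 nM, and compound 3 `CC1(C)[C@H]2CC[C@]1(C)N(Cc1cn(-c3ccc(O)cc3)nn1)C(=O)C2` gives 140 nM. Compound 3 lies within the scatter of both others, as a 1.6-fold lower number from compound 1 to compound 3 (0.22 log units; within the scatter) and a 2.0-fold higher number from compound 2 to compound 3 (0.30 log units; within the scatter) show. Compound 4 `CC1(C)[C@H]2CC[C@]1(C)N(Cc1cn(-c3ccccc3O)nn1)C(=O)C2` has 2-hydroxyphenyl in place of 4-hydroxyphenyl on an aromatic nitrogen. The nearest guide is a 3.3-fold lower number from compound 1 to compound 2 (0.52 log units; beyond the scatter), which swaps 4-fluorophenyl for 2-chlorophenyl. That step changes the group as well as its place, so it is only a weak hint. A small step is therefore expected in this assay, namely a 1.4-fold lower number from compound 3 to compound 4 (0.15 log units; within the scatter). Compound 4 is expected to give 100 nM, within an estimated range of 40 nM to 250 nM.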

Compound 4, half-maximal inhibitory concentration: 230 nM
Beside the measured number, compound 4's estimate is 2.3-fold (0.36 log units) below it; low and high end bracket the measured number.
By their numbers in this assay, from the lowest: compounds 2, 3, 1 and 4 (each within the scatter of the next, the first and the last beyond it).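

In this assay, shifting the hydroxy group around the phenyl ring gives a 1.6-fold higher number from compound 3 to compound 4 (0.22 log units; within the scatter) and so leaves 4-hydroxyphenyl and 2-hydroxyphenyl indistinguishable. The group itself matters more in this series: hydroxy in place of chloro gives a 3.3-fold higher number from compound 2 to compound 4 (0.52 log units; beyond the scatter) and is the clearest step involving compound 4, while the comparison with the fluorinated compound gives no change at the digits printed from compound 1 to compound 4 (within the scatter) as its result. Nothing measured here accounts for these steps.

On these data alone, whether 2-aminophenyl or 2-methoxyphenyl would sit nearer compound 2 or compound 4 remains open. So does whether chloro keeps its value in 4-chlorophenyl.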